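Piperazine aryl swap in the tetralin-propyl series

A few compounds are considered here, and "the series" means these few. Any claim that something is new, unique, unknown or untested is made for them only; others in the source may bear on it.

Working notes. The series has a propyl chain linking a bicyclic carbocycle to a piperazine that carries an aromatic group on its second nitrogen. Compound 1 `COc1ccccc1N1CCN(CCCC2CCCc3ccccc32)CC1` belongs to the set, but in an assay on isolated protein (Cavia porcellus) for binding affinity to Sigma non-opioid intracellular receptor 1 (Homo sapiens), read by radioligand binding (on this read-out higher numbers stand for weaker inhibition and lower numbers for stronger inhibition), compound 1 shows "not tested" (no result reported). Compound 3 `COc1cccc2c1CCCC2CCCN1CCN(c2cccc(C(F)(F)F)c2)CC1` likewise belongs to the set, and in this assay compound 3 shows "not tested" (no result reported). Neither of them gives a number to work from. For the measured compounds named here, compound 2 `COc1ccc2c(c1)C(CCCN1CCN(c3ccccc3OC)CC1)=CCC2` is the only member with a value: in this assay compound 2 gives 228 nM, and it therefore stands alone as the single reference point, with no second measured compound against which a step could be read.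

Compound 4 `COc1ccc2c(c1)C(CCCN1CCN(c3ccccn3)CC1)=CCC2` is the next entry to be measured. The change from compound 2 is pyridin-2-yl in place of 2-methoxyphenyl on an amine nitrogen in a ring. Going by the values given here, no measured pair in the set shows what this kind of exchange does here, so the expectation rests only on the reference value of compound 2 and the nature of the swap. A moderate step toward weaker binding is expected in this assay, probably somewhat beyond the usual scatter but not large. The step from compound 2 to compound 4 is estimated at a 2.6-fold higher number from compound 2 to compound 4 (0.42 log units; beyond the scatter). Compound 4 is expected to give 600 nM in this assay, within a range from 150 nM to 2500 nM.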

Compound 4, half-maximal inhibitory concentration: 246 nM
Estimate against measurement, compound 4: 2.4-fold (0.39 log units) above; measured number inside the range.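

In this assay, for the compounds shown here, pyridin-2-yl in place of 2-methoxyphenyl on the amine nitrogen in the ring gives a 1.1-fold higher number from compound 2 to compound 4 (0.03 log units; within the scatter), the first step that can be read at this position. For this one pair, the read-out does not separate the two groups, although the leaving group is an aromatic ring of carbon only with 8 heavy atoms and the entering group is an aromatic ring with 1 hetero atom and 6 heavy atoms. No supporting measurement bears on this result, so the data give no explanation for it.

Going by these compounds alone, compound 1 and compound 3 carry no number in this assay, so no step involving either of them can be read, and whether the same exchange would read alike on the core of either compound stays open. A single pair also leaves open how other groups on this nitrogen would read, such as unsubstituted phenyl, pyrimidin-2-yl or a benzyl group, so no trend at this position can be stated yet.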